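Widening a Small Ring on a Vitamin D Receptor Antagonist

A few compounds are considered here, and "the series" means these few. Any claim that something is new, unique, unknown or untested is made for them only; others in the source may bear on it.

Compound 1 `CC(C)c1onc(-c2c(Cl)cccc2Cl)c1COc1ccc(-c2nc3ccc(C(=O)O)cc3n2C2CC2)cc1` gives 3200 nM in an assay on HEK-293T cells for antagonist activity at vitamin D3 receptor (Homo sapiens), read by a luciferase reporter, with a stated time of 24 h; on this read-out lower numbers stand for stronger inhibition and higher numbers for weaker inhibition. Compound 2 `CC(C)c1onc(-c2c(Cl)cccc2Cl)c1COc1ccc(-c2nc3ccc(C(=O)O)cc3n2C)cc1Cl` gives 2450 nM in this assay. Of the two numbers, compound 1's is the higher, though the gap to compound 2 lies within the usual scatter. Compound 3 `CC(C)c1onc(-c2c(Cl)cccc2Cl)c1COc1ccc(-c2nc3ccc(C(=O)O)cc3n2C2CCC2)cc1` differs from compound 1 by cyclobutyl in place of cyclopropyl on an aromatic nitrogen. Among the compounds with values here, no measured pair shows this change, so the expectation is a step no larger than the scatter, in either direction. The step from compound 1 to compound 3 is estimated at a 1.1-fold lower number from compound 1 to compound 3 (0.03 log units; within the scatter). Compound 3 is expected to give 3000 nM, within a range of 1200 nM to 7500 nM.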

Compound 3, half-maximal inhibitory concentration: 1100 nM
Compound 3: middle estimate off by 2.7-fold (0.44 log units), on the high side; the measured number lies below the stated range.
By their numbers in this assay, from the lowest: compound 3; then compounds 2 and 1 (each within the scatter of the next).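

In this assay cyclobutyl in place of cyclopropyl on the aromatic nitrogen brings a 2.9-fold lower number from compound 1 to compound 3 (0.46 log units; beyond the scatter) and so one more ring carbon here is enough to move the number beyond the scatter. The earlier compounds shown here offered no pair that tested this position, and this step shows that the number responds to the group placed there. No measurement at hand explains the step. As far as these compounds go, what remains open is whether a larger ring such as cyclopentyl would extend the step. Equally open, from the compounds shown here alone, is how an open chain such as n-butyl would compare with either ring.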